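Plasma protein binding: methanesulfonamido in place of methoxy

The compounds below may be only part of what the source reports. "The series", "measured", "known", "first", "only" and "open" are said of these compounds alone.

In an ADME assay on a cell-free system (plasma, Homo sapiens) for protein binding, read by LC-MS, with a stated time of 5 h, tested at 10 uM, compound 1 `COc1ccc2c(ccn2-c2ccc(O[C@H]3O[C@H](CO)[C@@H](O)[C@H](O)[C@@H]3O)c(Cl)c2)c1` gives 96% and compound 2 `OC[C@H]1O[C@H](Oc2ccc(-n3ccc4ccccc43)cc2F)[C@@H](O)[C@@H](O)[C@@H]1O` gives 98%, two values within the scatter of each other. Compound 3 `CS(=O)(=O)Nc1ccc2c(ccn2-c2ccc(O[C@H]3O[C@H](CO)[C@@H](O)[C@H](O)[C@@H]3O)c(Cl)c2)c1` carries methanesulfonamido in place of methoxy on an aromatic carbon of the core of compound 1 (methanesulfonamido in place of methoxy on an aromatic carbon). Among the compounds with values here, no measured pair covers this change, so the expectation is loose. In this assay the expected step is a 1.5-fold higher unbound fraction from compound 1 to compound 3 (0.18 log units; within the scatter), towards more free compound, and it probably stays within the scatter. For compound 3 the estimated value is 94%, with an expected range of 85% to 98%.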

Compound 3, plasma protein binding: 94%
Estimate against measurement, compound 3: no gap at the digits printed, and the stated range covers the measured number.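

In this assay, methanesulfonamido in place of methoxy on this aromatic carbon of the shared core gives a 1.5-fold higher unbound fraction from compound 1 to compound 3 (0.18 log units; within the scatter) and adds a hydrogen-bond donor and more heavy atoms, so this position takes the larger group without a step beyond the scatter. Within the data shown here, this is the first single-place comparison, and nothing measured explains the size of the step. Open, on these data alone, is whether an amine or a carboxylic acid on this same carbon would move binding beyond the scatter.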